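The source may report more compounds than this note shows. Statements on the series, on what has been measured and on what is new or still open speak of the compounds shown alone.

Of the compounds shown here, three sharing one core have been tested in a functional assay on SNB-19 cells (Homo sapiens) for inhibition, read by sulforhodamine B assay, with a stated time of 48 h; on this read-out higher numbers stand for weaker inhibition of growth and lower numbers for stronger inhibition of growth. Compound 1 `O=C(Nc1cccc(-n2cc(-c3ccncc3)c(-c3ccc(Cl)c(O)c3)n2)c1)Nc1cccc(C(F)(F)F)c1` carries a hydroxy group. For compound 1 this assay returns only a limit, > 32500 nM, rather than a number (the limit of > 32500 nM in this assay, at which 1 of the 3 values shown sits). Compound 3 `COc1cc(-c2nn(-c3cccc(NC(=O)Nc4cccc(C(F)(F)F)c4)c3)cc2-c2ccncc2)ccc1Cl` differs from compound 1 in having methyl in place of hydrogen on that oxygen; in this assay compound 3 gives 4000 nM, so the step of an at least 8.1-fold lower number from compound 1 to compound 3 (0.90 log units; beyond the scatter). Compound 2 `COc1cc(-c2nn(-c3cccc(NC(=O)Nc4cc(C(F)(F)F)cc(C(F)(F)F)c4)c3)cc2-c2ccncc2)ccc1Cl` differs from compound 3 by a second trifluoromethyl, and in this assay compound 2 gives 3670 nM, a step of a 1.1-fold higher number from compound 2 to compound 3 (0.04 log units; within the scatter). Compound 2 thus holds the smaller of the two numbers shown, though the gap to compound 3 sits within the scatter.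

Compound 4 `O=C(Nc1cccc(-n2cc(-c3ccncc3)c(-c3ccc(Cl)c(O)c3)n2)c1)Nc1cc(C(F)(F)F)cc(C(F)(F)F)c1` is related to compound 2 by hydrogen in place of methyl on an oxygen on an aromatic ring, that is, methoxy to hydroxy, turning 4-chloro-3-methoxyphenyl into 4-chloro-3-hydroxyphenyl. This is the change from compound 1 to compound 3 run backwards, and that step was large, so a step of comparable size toward a higher number is expected here. Compound 4 is therefore estimated at 32000 nM, within a range from 14000 nM to 100000 nM. The expected step is an 8.7-fold higher number from compound 2 to compound 4 (0.94 log units; beyond the scatter). The number may well come back only as a limit.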

Compound 4, concentration for total growth inhibition: 8960 nM
Compound 4: middle estimate off by 3.6-fold (0.55 log units), on the high side; measured number outside the range, below it.
By their numbers in this assay, from the lowest: compounds 2 and 3 (each within the scatter of the next); then compound 4. At a limit, above all of these: compound 1.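

Going from methoxy to hydroxy still weakens growth inhibition when the second trifluoromethyl is present, with a 2.4-fold higher number from compound 2 to compound 4 (0.39 log units; beyond the scatter), but the loss is smaller than the one the earlier pair suggested: the same change on two cores in this assay, an at least 8.1-fold lower number (0.90 log units; beyond the scatter) from compound 1 to compound 3 and a 2.4-fold lower number (0.39 log units; beyond the scatter) from compound 4 to compound 2, at least 3.3-fold (0.52 log units) apart, beyond the scatter of two such steps. Adding the second trifluoromethyl, which changed nothing measurable on the methoxy compounds, does matter on the hydroxy compounds, with an at least 3.6-fold lower number from compound 1 to compound 4 (0.55 log units; beyond the scatter), so the effect of each change depends on the other: the same change on two cores in this assay, a 1.1-fold higher number (0.04 log units; within the scatter) from compound 2 to compound 3 and an at least 3.6-fold higher number (0.55 log units; beyond the scatter) from compound 4 to compound 1, at least 3.3-fold (0.52 log units) apart, beyond the scatter of two such steps. In this assay, from the compounds shown here alone, compound 1 gives > 32500 nM, which is a limit and not a number, so the real size of its steps stays unknown.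

These four compounds show that the two changes interact, but not why they do, and a pattern resting on a single square of compounds may not extend further. Going by these compounds, whether a longer chain on that oxygen, such as ethyl, behaves like methyl or like hydrogen remains open, as does the outcome with an amine in place of the hydroxy group or a nitrile in place of the second trifluoromethyl.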